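The source may report more compounds than this note shows. Statements on the series, on what has been measured and on what is new or still open speak of the compounds shown alone.

Compound 1, `CCN1CCc2c(c(C(C)(C)C)nn2C(=O)Nc2ccc(Br)cc2)C1`: 72.1%
Compound 2, `CCN1CCc2c(c(C(C)(C)C)nn2C(=O)Nc2c(C)cccc2C)C1`: 68%
Compound 3, `CCN1CCc2c(c(C(C)(C)C)nn2C(=O)Nc2cc(C)ccc2F)C1`: 60.5%

Of the compounds shown here, three sharing one core have been tested in a functional assay on the whole organism (strain Swiss albino) for inhibition, with Mus musculus as the target, in the formalin test, with a stated time of 30 min, at a dose of 100 mg/kg; a higher number here means more inhibition at the dose given (going by the name of the read-out), a lower number less inhibition. Compound 3, with its 2-fluoro-5-methylphenyl on the amide-type nitrogen, gives the lowest of the three numbers. Its nearest neighbour is compound 2, and the gap between them, a number 7.5 percentage points lower from compound 2 to compound 3 (within the scatter), lies within the scatter, so the two cannot be put in order. The gap to compound 1 is larger: a number 11.6 percentage points lower from compound 1 to compound 3 (beyond the scatter), a step beyond the scatter. The step of a number 4.1 percentage points lower from compound 1 to compound 2 (within the scatter) is within the scatter.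

Compound 4, `CCN1CCc2c(c(C(C)(C)C)nn2C(=O)Nc2ccc(Cl)cc2)C1`, is not yet measured. It differs from compound 3 as follows: 4-chlorophenyl in place of 2-fluoro-5-methylphenyl on an amide-type nitrogen. Within the data shown here, the step that bears most on this change is the one from compound 1 to compound 3, since compound 1 also carries a single halogen on its phenyl, in the 4-position, and its replacement by 2-fluoro-5-methylphenyl lowered the number beyond the scatter. Going the other way, from 2-fluoro-5-methylphenyl to 4-chlorophenyl, a rise of about that size is therefore expected in this assay , roughly back toward the value of compound 1; the step is estimated at a number 9.5 percentage points higher from compound 3 to compound 4 (within the scatter). Compound 4 is thus expected to give 70%, with a range from 58% to 80%.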

Compound 4, a percentage reported as inhibition, in the whole organism at one dose (the size of the read-out at that dose, not a potency): 68.3%
Estimate against measurement, compound 4: 1.7 percentage points above; the measured number falls inside the stated range.
By their numbers in this assay, from the lowest: compounds 3, 2, 4 and 1 (each within the scatter of the next, the first and the last beyond it).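

In this assay, among these compounds, the step of a number 3.8 percentage points lower from compound 1 to compound 4 (within the scatter) is the first exchange of one halogen for another at this place, on an aromatic carbon of the phenyl on the amide-type nitrogen, and it shows that 4-chlorophenyl and 4-bromophenyl cannot be told apart here. Among the compounds shown here, the steps of a number 7.8 percentage points higher from compound 3 to compound 4 (within the scatter) and a number 0.3 percentage points higher from compound 2 to compound 4 (within the scatter) leave 4-chlorophenyl unordered against both 2-fluoro-5-methylphenyl and 2,6-dimethylphenyl, so the gap beyond the scatter between compound 1 and compound 3 has no counterpart between compound 4 and compound 3, and that single gap is now the only separation among the four compounds. No measured property of these compounds bears on the result, so the numbers stand without an explanation.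

All four compounds carry a phenyl with only halogen or methyl groups on it, which leaves open how a phenyl bearing a methoxy group, a dimethylamino group or a carboxylic acid, or a cyclohexyl in place of the phenyl, would behave at this nitrogen. Also open, from the compounds shown here alone, is whether the picture holds at other doses, and how changes elsewhere on the shared core would read.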